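The compounds below may be only part of what the source reports. "The series", "measured", "known", "first", "only" and "open" are said of these compounds alone.

Values in an ADME assay on HepG2 cells (Homo sapiens) for cytotoxicity, read by CellTiter-Glo and resazurin assay, with a stated time of 72 h (on this read-out higher numbers stand for an effect only at larger amounts of compound and lower numbers for an effect already at smaller amounts), for the measured members of the series:

compound 1, `CCOC(=O)CCCCCOc1cccc(CN(C(=O)c2ccccc2)C(C)C)c1`: > 26000 nM, a limit of the assay.
compound 2, `CCOC(=O)CCCCCOc1cccc(CN(C(=O)c2ccc(-c3cccc(NC(C)=O)c3)cc2)C(C)C)c1`: > 26000 nM, a limit of the assay.
compound 3, `CCOC(=O)CCCCCOc1cccc(CN(C(=O)c2ccc(-c3cccnc3)cc2)C(C)C)c1`: > 26000 nM, a limit of the assay.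

Compound 2 therefore stands at the limit and not at a number; (the limit of > 26000 nM in this assay, at which 3 of the 3 values shown sit), so none of the three measured compounds gives a readable value here. The step from compound 2 to compound 4, `CCOC(=O)CCCCCOc1cccc(CN(C(=O)c2ccc(-c3cccc(OCc4ccccc4)c3)cc2)C(C)C)c1`, is benzyloxy in place of acetamido on an aromatic carbon. Among the compounds with values here, the steps that bear on this change are those around the same aromatic carbon: a step that the two limits leave unreadable from compound 1 to compound 2, a step that the two limits leave unreadable from compound 2 to compound 3 and a step that the two limits leave unreadable from compound 1 to compound 3. Within the data shown here, all three sit between limits, so their size cannot be read, and no measured step shows that a substituent at this position moves the read-out. Nothing in the measured compounds points to a step beyond the scatter in either direction, and the expected result for compound 4 is estimated as a step that the limit leaves unreadable from compound 2 to compound 4, that is, essentially none. For compound 4 the estimate in this assay is 40000 nM, expected to fall between 15000 nM and 120000 nM, with a real chance that only a limit is reported again.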

Compound 4, half-maximal effective concentration: > 26000 nM
Compound 4: only a limit was reported; the forecaster's own chance of this, stated with the estimate: 80%; the middle value does not contradict the limit.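

In this assay compound 4 gives > 26000 nM, a limit of the assay. No size can be read for the change from compound 2 to compound 4, benzyloxy in place of acetamido, since both stand at a limit: the limit of > 26000 nM in this assay, at which 4 of the 4 values shown sit.

The compounds shown leave open whether any substituent at this aromatic carbon moves the read-out.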